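Trimming one ring on compound 3

This account rests on a few compounds, and the source may have more. Where it says the series, first, only, none or still open, it means among the compounds named here.

Measured in an in vitro ADME assay on microsomes from liver (Homo sapiens) for metabolic stability, tested at 5 uM; on this read-out higher numbers stand for a longer-lived compound and lower numbers for a shorter-lived compound:
compound 1 `CS(=O)(=O)Nc1ccc2c(c1)S(=O)(=O)N=C(c1c(O)c(-c3ccsc3)nn(CCC3CC3)c1=O)N2`: 0.517 h
compound 2 `CC(C)CCn1nc(C2CCCCC2)c(O)c(C2=NS(=O)(=O)c3cc(NS(C)(=O)=O)ccc3N2)c1=O`: 0.117 h
compound 3 `CS(=O)(=O)Nc1ccc2c(c1)S(=O)(=O)N=C(c1c(O)c(-c3cccs3)nn(CC3CCC3)c1=O)N2`: > 1 h (a limit)

Compound 3 carries only a limit, > 1 h, and not a number. Its standing among the three is brief: the limit of > 1 h in this assay, at which 1 of the 3 values shown sits. The other two compounds give numbers, with compound 1 at 0.517 h and compound 2 at 0.117 h. From the compounds shown here alone, compound 3 therefore sits on the long-lived side of both, though how far remains unknown.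

The next compound, compound 4 `CS(=O)(=O)Nc1ccc2c(c1)S(=O)(=O)N=C(c1c(O)c(-c3cccs3)nn(CC3CC3)c1=O)N2`, departs from compound 3 in a single place: cyclopropyl in place of cyclobutyl on a saturated chain carbon bound to an aromatic nitrogen. This puts cyclopropyl in place of cyclobutyl on a saturated chain carbon bound to an aromatic nitrogen, so that cyclobutylmethyl becomes cyclopropylmethyl.

Among the compounds with values here, no two measured compounds differ in only one place, so the series offers no measured step to serve as a guide. In this assay the expectation is therefore for no change beyond the scatter, with a slight lean toward a shorter-lived compound. The estimated size of the change, an at least 1.1-fold lower number from compound 3 to compound 4 (0.04 log units; that floor lies within the scatter), is expected to be small. Compound 4 is expected at 0.9 h, with an estimated range from 0.4 h to 2 h.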

Compound 4, half-life: > 1 h
Compound 4 ended at the assay's limit (the forecaster's own chance of this, stated with the estimate: 45%); middle value at least 1.1-fold (0.04 log units) from the limit.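

In this assay compound 3 gives > 1 h, a limit and not a number. Compound 4 likewise gives a limit, > 1 h. Within the data shown here, no step can therefore be read from compound 3 to compound 4. The compounds shown leave open how the half-lives of these two compare, as the series now stands at: the limit of > 1 h in this assay, at which 2 of the 4 values shown sit.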